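A few compounds are considered here, and "the series" means these few. Any claim that something is new, unique, unknown or untested is made for them only; others in the source may bear on it.

Of the compounds shown here, three built on one shared core have been tested in an ADME assay on PC-3 cells (Homo sapiens) for cytotoxicity, read by WST assay, tested at 100 uM; on this read-out higher numbers stand for more inhibition at the one concentration tested (going by the name of the read-out) and lower numbers for less inhibition. Compound 1 `O=C(Nc1cccc(Oc2ccccn2)c1)C1CCCN(C(=O)c2cc(C(F)(F)F)cc(C(F)(F)F)c2)C1` carries a (pyridin-2-yl)oxy group on its outer aromatic ring; in this assay compound 1 gives 0%. Compound 2 `CSc1cccc(C(=O)N2CCCC(C(=O)Nc3ccc(Cl)cc3)C2)c1` gives 0%, and compound 3 `N#Cc1cccc(C(=O)N2CCCC(C(=O)Nc3ccc(Cl)cc3)C2)c1` gives 0%. Compound 1 therefore stands level with compounds 2 and 3 at the digits shown, within the scatter of both. Going by the values given here, the only step joining two measured compounds, cyano in place of methylsulfanyl on an aromatic carbon, runs no change at the digits printed from compound 2 to compound 3 (within the scatter).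

Compound 4 `O=C(Nc1cccc([N+](=O)[O-])c1)C1CCCN(C(=O)c2cc(C(F)(F)F)cc(C(F)(F)F)c2)C1` is the one still to be measured. It differs from compound 1 in a single place: nitro in place of (pyridin-2-yl)oxy on an aromatic carbon. Among the compounds with values here, no measured pair shows this particular exchange, so nothing here speaks to it directly. What the data do show is that swapping one small group for another on an aromatic carbon left the read-out unchanged, and that all three measured compounds show no inhibition at the tested concentration. On that basis the step of no change at the digits printed from compound 1 to compound 4 (within the scatter) is expected to stay within the scatter, with no direction to it. For compound 4 the estimate in this assay is 0%, expected to fall between -10% and 15%.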

Compound 4, a percentage reported as inhibition, at one concentration (the size of the read-out at that concentration, not a potency): 9%
For compound 4 the middle estimate is 9 percentage points below the measured one, within the range that was stated.
By their numbers in this assay, from the lowest: compounds 1, 2, 3 and 4 (each within the scatter of the next).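

Putting nitro in place of (pyridin-2-yl)oxy on this aromatic carbon, meta to a large group, gives a number 9 percentage points higher from compound 1 to compound 4 (within the scatter) in this assay. This exchange removes a whole six-membered aromatic ring with 1 hetero atom and replaces a group of 7 heavy atoms with one of 3, yet the two compounds remain within the scatter of each other, so this pair gives no sign at the one concentration tested that the read-out depends on that ring or on the larger group at this position. No measurement is available that would explain the result for this pair.

Still open, from the compounds shown here alone, is whether a group of another kind on this same carbon, such as an amine or a carboxylic acid, would also keep the read-out within the scatter of compound 1. Going by these compounds, this exchange also rests on a single pair, so whether it would read the same way on a different core remains unknown, as does how either compound would behave at any other concentration.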